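Swapping the oxazole for a methylimidazole on a shared core

The source may hold more compounds than are shown below. What is called first, only, known or untested is meant among the compounds shown, and "the series" means these compounds.

Measured compounds:
`CCCC[S+]([O-])c1sc2nc(-c3ncco3)cc(-c3ccccc3)c2c1N` compound 1, 1.4 nM
`CCCC[S+]([O-])c1sc2nc(-c3nccs3)cc(-c3ccc(CN)cc3)c2c1N` compound 2, 11.5 nM

In an assay for inhibition of 15-hydroxyprostaglandin dehydrogenase [NAD(+)] (Homo sapiens), read by fluorescence, with a stated time of 15 min, in the presence of a further agent that is not named here (on this read-out higher numbers stand for weaker inhibition and lower numbers for stronger inhibition), compound 1 holds the lowest number of the two, and compound 2 sits well beyond the scatter from it. The unmeasured compound 3 `CCCC[S+]([O-])c1sc2nc(-c3nccn3C)cc(-c3ccccc3)c2c1N` differs from compound 1 only in one place: 1-methyl-1H-imidazol-2-yl in place of 1,3-oxazol-2-yl on an aromatic carbon. Among the measured compounds shown here, no single-change step between measured compounds is available to calibrate this change. Compound 3 is therefore expected to stay close to compound 1, with a modest step toward weaker inhibition that may not exceed the scatter, a 2.1-fold higher number from compound 1 to compound 3 (0.33 log units; beyond the scatter). The estimate for compound 3 is 3 nM, within 0.8 nM to 12 nM.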

Compound 3, half-maximal inhibitory concentration in the 15-hydroxyprostaglandin dehydrogenase [NAD(+)] assay: 6.7 nM
Compound 3: middle estimate off by 2.2-fold (0.35 log units), on the low side; measured number inside the range.
By their numbers in the 15-hydroxyprostaglandin dehydrogenase [NAD(+)] assay, from the lowest: compound 1; then compounds 3 and 2 (each within the scatter of the next).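

In the 15-hydroxyprostaglandin dehydrogenase [NAD(+)] assay placing 1-methyl-1H-imidazol-2-yl where 1,3-oxazol-2-yl stood, next to the ring nitrogen, gives a 4.8-fold higher number from compound 1 to compound 3 (0.68 log units; beyond the scatter) and so shows that this position responds to the exchange of one five-membered aromatic ring for another. In a physicochemical assay for solubility, read by LC-MS, with a stated time of 16 h, at pH 7 (on this read-out higher numbers stand for higher solubility and lower numbers for lower solubility), the same change gives a 1.5-fold lower number from compound 1 to compound 3 (0.17 log units; within the scatter) and does not separate the two compounds: compound 1 gives 2.8 ug/mL and compound 3 gives 1.9 ug/mL. Nothing at hand explains the step in inhibition. The compounds shown leave open whether the methyl group or the ring exchange carries the step. A 1H-imidazol-2-yl group without the methyl would address that.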